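The compounds below may be only part of what the source reports. "The series", "measured", "known", "first", "only" and "open" are said of these compounds alone.

Measured in a functional assay on DU-145 cells (Homo sapiens) for antiproliferative activity, read by MTT assay, with a stated time of 48 h; a lower number here means a stronger inhibitor, a higher number a weaker inhibitor:
- Compound 1 `COc1ccccc1-n1cc(COC(=O)/C(C)=C/CC/C(C)=C/CC/C(C)=C/CC[C@@H]2[C@@]3(C)CCC(=O)C(C)(C)[C@H]3CC[C@@]2(C)O)nn1`: > 150000 nM
- Compound 2 `C/C(=C\CC/C(C)=C/CC[C@@H]1[C@@]2(C)CCC(=O)C(C)(C)[C@H]2CC[C@@]1(C)O)CC/C=C(\C)C(=O)OCc1cn(-c2ccc(Br)cc2)nn1`: > 150000 nM
- Compound 3 `C/C(=C\CC/C(C)=C/CC[C@@H]1[C@@]2(C)CCC(=O)C(C)(C)[C@H]2CC[C@@]1(C)O)CC/C=C(\C)C(=O)OCc1cn(-c2ccccc2)nn1`: 95500 nM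

Compound 3 is the only one of these with an actual number, 95500 nM. Compound 1 has only a limit, > 150000 nM. Compound 2 has only a limit as well, > 150000 nM.

Compound 4 `COc1cccc(-n2cc(COC(=O)/C(C)=C/CC/C(C)=C/CC/C(C)=C/CC[C@@H]3[C@@]4(C)CCC(=O)C(C)(C)[C@H]4CC[C@@]3(C)O)nn2)c1` differs from compound 3 by one change: methoxy in place of hydrogen on an aromatic carbon, so phenyl becomes 3-methoxyphenyl.

For the measured compounds named here, two measured steps bear on this. The closer one also concerns a methoxy, though compound 1 carries it elsewhere on the ring: an at least 1.5-fold lower number from compound 1 to compound 3 (0.19 log units; that floor lies within the scatter). The other concerns a bromo: an at least 1.5-fold lower number from compound 2 to compound 3 (0.19 log units; that floor lies within the scatter). Both point the same way, but their floors lie within the scatter. In this assay, adding methoxy is therefore expected to raise the number slightly, if at all.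

The expected step is a 1.4-fold higher number from compound 3 to compound 4 (0.13 log units; within the scatter). Compound 4 may also be expected to end at a limit, given (the limit of > 150000 nM in this assay, at which 2 of the 3 values shown sit). For compound 4 the estimated value is 130000 nM, with an expected range from 60000 nM to 250000 nM.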

Compound 4, half-maximal inhibitory concentration: > 150000 nM
Compound 4 gave a limit, no number; the forecaster's own chance of this, stated with the estimate: 50%; middle value at least 1.1-fold (0.06 log units) from the limit.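

In this assay compound 4 gives > 150000 nM, which is a limit and not a number. Methoxy meta to a large group gives an at least 1.5-fold higher number from compound 3 to compound 4 (0.19 log units; that floor lies within the scatter), so this ring carbon, like the substituted ring carbons of compound 1 and compound 2, shows no gain over the plain phenyl ring; the steps among compound 1, compound 2 and compound 4 cannot be read, with limits at both ends. Of the four compounds, only compound 3 now has a measured number, and the others share one ceiling: the limit of > 150000 nM in this assay, at which 3 of the 4 values shown sit.

Going by these compounds, the order of compound 1, compound 2 and compound 4 stays open, as does how far each lies from the limit. Also open, on these data alone, is whether a hydroxyl, an amine or a carboxylic acid on the same ring carbon would bring the number down.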